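The source may hold more compounds than are shown below. What is called first, only, known or untested is meant among the compounds shown, and "the series" means these compounds.

Measured compounds in a functional assay on HCT-116 cells (Homo sapiens) for cytotoxicity, read by sulforhodamine B assay, with a stated time of 24 h; on this read-out higher numbers stand for weaker inhibition and lower numbers for stronger inhibition:
- compound 1 `O=C(CCC(c1c[nH]c2ccccc12)c1c[nH]c2ccccc12)NO` gives > 20000 nM, a limit of the assay, not a number
- compound 2 `O=C(CCCCC(c1c[nH]c2ccccc12)c1c[nH]c2ccccc12)NO` gives 5800 nM

Within the data shown here, compound 2 carries the only number in this assay; the other value is a limit (the limit of > 20000 nM in this assay, at which 1 of the 2 values shown sits). Among the measured compounds shown here, the single measured step, an at least 3.4-fold lower number from compound 1 to compound 2 (0.53 log units; beyond the scatter), concerns chain length only. Compound 3 `O=C(CCCCCc1c[nH]c2ccccc12)NO` differs from compound 2 by hydrogen in place of 1H-indol-3-yl on a saturated chain carbon bound to an aromatic carbon and a saturated chain carbon. For the measured compounds named here, no measured step touches this change, so the direction and size rest on judgment alone. A weakening step is expected, a 2.6-fold higher number from compound 2 to compound 3 (0.41 log units; beyond the scatter). Compound 3 is expected near 15000 nM, within 5000 nM to 50000 nM, with a fair chance that only a limit is reported.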

Compound 3, half-maximal inhibitory concentration: 15000 nM
Estimate against measurement, compound 3: no gap at the digits printed; low and high end bracket the measured number.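

In this assay, hydrogen in place of 1H-indol-3-yl on a saturated chain carbon bound to an aromatic carbon and a saturated chain carbon gives a 2.6-fold higher number from compound 2 to compound 3 (0.41 log units; beyond the scatter). Among these compounds, this is the first reading at this carbon, as the earlier step concerned chain length only, and it shows that the lost 1H-indol-3-yl counts towards the lower number. Even without that group, compound 3 still gives a number, not a limit.

Compound 1 remains a limit, so its step has no exact size: the limit of > 20000 nM in this assay, at which 1 of the 3 values shown sits. Open, from the compounds shown here alone, is how a longer chain, or a phenyl or an amine on this carbon, would read.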